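The compounds below may be only part of what the source reports. "The series", "measured", "known", "first", "only" and "open" are said of these compounds alone.

Working notes on the series.

Compound 1 `CCOC(=O)c1[nH]c2ccc(Cl)cc2c1C(=O)c1cc(OC)c(OC)c(OC)c1N` and compound 2 `CCOC(=O)c1[nH]c2ccc(Br)cc2c1C(=O)c1cc(OC)c(OC)c(OC)c1N` share one core and differ only in bromo in place of chloro on an aromatic carbon. In a functional assay on MCF7 cells (Homo sapiens) for cytotoxicity, read by sulforhodamine B assay, with a stated time of 48 h (on this read-out higher numbers stand for weaker inhibition of growth and lower numbers for stronger inhibition of growth), compound 1 gives 590 nM. In the same assay compound 2 gives 425 nM. For the measured compounds named here, the step of a 1.4-fold lower number from compound 1 to compound 2 (0.14 log units; within the scatter) is the only measured instance of this exchange, and it leaves the two values within the usual scatter of each other, so no ordering of the two is claimed.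

Compound 3 `COc1cc(Cc2c[nH]c3ccc(Cl)cc23)c(N)c(OC)c1OC` is built on a different core; the difference between the two cores is not broken down here. In this assay compound 3 was reported as "not active" (no number reported), and no concentration for growth inhibition was given for it.

Compound 4 `COc1cc(Cc2c[nH]c3ccc(Br)cc23)c(N)c(OC)c1OC` has not yet been measured. It stands to compound 3 exactly as compound 2 stands to compound 1: the change is bromo in place of chloro on an aromatic carbon, and the place is described in the same words as for the measured pair, so this is the same change, occurring twice among the four compounds.

For compound 4 in this assay the expectation is that the outcome again lies outside the range in which a concentration can be assigned, or at best at a very weak level. The expected value for compound 4 is 60000 nM. The expected range for compound 4 runs from 10000 nM to 300000 nM. This rests on compound 3 being reported as "not active" (no number reported) and on the size of the step of a 1.4-fold lower number from compound 1 to compound 2 (0.14 log units; within the scatter), which shows no gain from the same exchange on the other core.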

Compound 4, concentration for 50% growth inhibition: "not active" (no number reported)
Compound 4 has no reported number here; there is nothing to compare the estimate with.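

For the compounds shown here, compound 3 and compound 4 are both reported as "not active" in this assay, with no number for either, so no step between them can be read. The compounds shown leave open which of the differences between the core of compound 1 and the core of compound 3 goes with a measurable concentration. No available data bear on this result.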